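Trimming the Side Chain Back to a Hydroxymethyl

The source may hold more compounds than are shown below. What is called first, only, known or untested is meant among the compounds shown, and "the series" means these compounds.

Compound 1 `CC(C)=CCC[C@H](C)c1ccc(C)cc1O` is the bare core. In a functional assay on MDA-MB-231 cells (Homo sapiens) for inhibition, read by MTT assay, with a stated time of 72 h (a higher number here means a weaker inhibitor, a lower number a stronger inhibitor), compound 1 reaches only the assay limit, > 50000 nM. Compound 2 `CC(C)=CCC[C@H](C)c1ccc(C)c(CNCCO)c1O` gives 14400 nM in this assay, and compound 3 `CC(C)=CCC[C@H](C)c1ccc(C)c(CNCCCCCO)c1O` gives 10700 nM, a number that differs from compound 2 by a 1.3-fold lower number from compound 2 to compound 3 (0.13 log units; within the scatter). Putting such groups onto the core gave an at least 3.4-fold lower number from compound 1 to compound 2 (0.54 log units; beyond the scatter) and an at least 4.6-fold lower number from compound 1 to compound 3 (0.66 log units; beyond the scatter). Compound 4 `CC(C)=CCC[C@H](C)c1ccc(C)c(CO)c1O` carries the change (hydroxy in place of (5-hydroxypentyl)amino on a saturated chain carbon bound to an aromatic carbon), so most of what those two steps added is taken away again. Those two steps bear on the outcome, and a move back toward weaker inhibition is expected, roughly a 2.8-fold higher number from compound 3 to compound 4 (0.45 log units; beyond the scatter). Compound 4 is therefore estimated at 30000 nM, with a range from 12000 nM to 60000 nM.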

Compound 4, half-maximal inhibitory concentration: 22200 nM
Estimate against measurement, compound 4: 1.4-fold (0.13 log units) above; the range from low to high includes it.
By their numbers in this assay, from the lowest: compounds 3, 2 and 4 (each within the scatter of the next, the first and the last beyond it). At a limit, above all of these: compound 1.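

A hydroxymethyl alone, with no amine nitrogen, still gives an at least 2.2-fold lower number from compound 1 to compound 4 (0.35 log units; beyond the scatter), so a step beyond the scatter at this position does not depend on the amino chains. Swapping the (5-hydroxypentyl)amino for hydroxy gives a 2.1-fold higher number from compound 3 to compound 4 (0.32 log units; beyond the scatter), a modest loss, while swapping the (2-hydroxyethyl)amino gives a 1.5-fold higher number from compound 2 to compound 4 (0.19 log units; within the scatter), which stays within the scatter. Compound 1 is held at a limit, so the step from it sets only a minimum size: the limit of > 50000 nM in this assay, at which 1 of the 4 values shown sits.

From the compounds shown here alone, what a carboxylic acid or a plain primary amine would give on this carbon stays open.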